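Swapping methyl for chloro on the aryl ring

The compounds below may be only part of what the source reports. "The series", "measured", "known", "first", "only" and "open" are said of these compounds alone.

Measured compounds:
compound 2 `Cc1ccccc1CCC1=NCCN1` 7360 nM
compound 1 `C1CCC(CCC2=NCCN2)CC1` 3570 nM

Within the data shown here, in an assay on membranes from kidney (strain Sprague-Dawley) for displacement of a labelled ligand from Nischarin (Rattus norvegicus) (on this read-out lower numbers stand for stronger inhibition and higher numbers for weaker inhibition), compound 2 gives 7360 nM, the highest of the two numbers known so far, and therefore the weaker of the two. Its nearest neighbour is compound 1, which in this assay gives 3570 nM, a lower number that lies beyond the scatter; the two compounds differ in more than one place, so this gap cannot be tied to a single change.

Compound 3 `Clc1ccccc1CCC1=NCCN1` has not yet been measured. It differs from compound 2 by one alteration: chloro in place of methyl on an aromatic carbon. Among the measured compounds shown here, nothing among the measured compounds isolates this change, so the expected size of the step rests on the change alone. Such a swap is expected to leave the number close to that of compound 2, perhaps a modest move towards a lower number, not clearly beyond the scatter. Compound 3 is estimated at 4000 nM, with a range from 1000 nM to 16000 nM.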

Compound 3, half-maximal inhibitory concentration: 4260 nM
The estimate for compound 3 lay 1.1-fold (0.03 log units) below the measured number, within the range that was stated.
By their numbers in this assay, from the lowest: compounds 1, 3 and 2 (each within the scatter of the next, the first and the last beyond it).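

In this assay, chloro in place of methyl on an aromatic carbon gives a 1.7-fold lower number from compound 2 to compound 3 (0.24 log units; within the scatter). Among these compounds, this is the first comparison here that isolates a single change, which the gap between compounds 1 and 2 could not do, and it shows that at this place, ortho to a group of 7 heavy atoms, the read-out does not separate these two groups of one heavy atom each. No measurement bearing on the reason for this result is available.

The compounds shown leave open whether a quite different group on this same aromatic carbon, such as an amine or a carboxylic acid, would give a step beyond the scatter. They also leave open whether chloro in place of methyl on another carbon of the ring would give a similar step.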